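Replacing a carbamate substituent at the piperidine carbonyl

The compounds below may be only part of what the source reports. "The series", "measured", "known", "first", "only" and "open" are said of these compounds alone.

Compound 1 `Cc1nc(S(C)(=O)=O)ccc1Oc1ncnc(OC2CCN(C(=O)OC3COC3)CC2)c1F` was tested in a functional assay on isolated protein for inhibition of Glucose-dependent insulinotropic receptor (Rattus norvegicus), read by HTRF and cAMP accumulation (on this read-out lower numbers stand for smaller maximal responses and higher numbers for larger maximal responses), and gave 66%. Its closest relative, compound 2 `Cc1nc(S(C)(=O)=O)ccc1Oc1ncnc(OC2CCN(C(=O)C3CCCC3)CC2)c1F`, gives 83% in this assay. Among these two numbers compound 1 is the lower one, and the step of a number 17 percentage points higher from compound 1 to compound 2 (beyond the scatter) is the only one measured so far; it came from putting cyclopentyl in place of (oxetan-3-yl)oxy on a carbonyl carbon.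

Compound 3 `Cc1nc(S(C)(=O)=O)ccc1Oc1ncnc(OC2CCN(C(=O)c3noc(C(C)C)n3)CC2)c1F` has not yet been measured. It differs from compound 1 as follows: 5-isopropyl-1,2,4-oxadiazol-3-yl in place of (oxetan-3-yl)oxy on a carbonyl carbon. The change thus sits at the same carbonyl carbon that was altered between compound 1 and compound 2, and again a group attached through oxygen leaves while a group attached through carbon enters. Among the compounds with values here, the single step that bears on it, a number 17 percentage points higher from compound 1 to compound 2 (beyond the scatter), was modest and upward, so a step of similar direction and size is expected here, although the entering group is a different kind of ring and the outcome could well stay within the scatter. For compound 3 the expected step is a number 12 percentage points higher from compound 1 to compound 3 (beyond the scatter), giving an estimated value of 78% with a range from 62% to 94%.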

Compound 3, largest response reached (reported as efficacy), in percent of the reference or control that the assay uses: 81%
Estimate against measurement, compound 3: 3 percentage points below; the range from low to high includes it.
By their numbers in this assay, from the lowest: compound 1; then compounds 3 and 2 (each within the scatter of the next).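

In this assay, a second ring attached through carbon at the carbonyl carbon, 5-isopropyl-1,2,4-oxadiazol-3-yl, gives a number 15 percentage points higher from compound 1 to compound 3 (beyond the scatter) when it takes the place of (oxetan-3-yl)oxy, so the upward step no longer rests on cyclopentyl alone. The two carbon-attached rings cannot be told apart on this read-out, since exchanging one for the other gives a number 2 percentage points lower from compound 2 to compound 3 (within the scatter), even though the five-membered aromatic ring with its hetero atoms looks quite different from cyclopentyl. Nothing available here explains either step.

Three compounds cannot show whether the lower maximal response of compound 1 belongs to attachment through oxygen in general or to the oxetane ring in particular: a simple isopropoxy group on the carbonyl carbon would separate those two readings, and a dimethylamino group would show how attachment through nitrogen compares. As far as these compounds go, it also remains open how much the isopropyl group on the oxadiazole contributes, which a methyl or a tert-butyl group in its place would begin to answer.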